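A few compounds are considered here, and "the series" means these few. Any claim that something is new, unique, unknown or untested is made for them only; others in the source may bear on it.

Compound 1 `O=C(Nc1cc(-c2ccccc2)[nH]n1)c1cccnc1Cl` and compound 2 `COc1ncccc1C(=O)Nc1cc(-c2ccccc2)[nH]n1` are built on one core, while compound 3 `O=C(Nc1cc(-c2ccc(Br)cc2)[nH]n1)c1ccc(Cl)nc1` and compound 4 `COc1ccc(C(=O)Nc2cc(-c3ccc(Br)cc3)[nH]n2)cn1` are built on another; the difference between the two cores is not broken down here. In a functional assay on A-375 cells (Homo sapiens) for antiproliferative activity, read by MTT assay, with a stated time of 48 h (on this read-out higher numbers stand for weaker inhibition and lower numbers for stronger inhibition), compound 1 gives 7340 nM, compound 2 gives 9940 nM and compound 3 gives 8890 nM, so the three measured numbers sit close together. The change from compound 1 to compound 2 is methoxy in place of chloro on an aromatic carbon, and it made a 1.4-fold higher number from compound 1 to compound 2 (0.13 log units; within the scatter). The change from compound 3 to compound 4 is methoxy in place of chloro on an aromatic carbon. It is the same kind of change, not the same one: in compound 2 the new group sits ortho to a large group, in compound 4 it sits para to a large group. Going by the values given here, with only one earlier example to go on, the step from compound 3 to compound 4 is expected to be a 1.2-fold higher number from compound 3 to compound 4 (0.09 log units; within the scatter), set beside a 1.4-fold higher number from compound 1 to compound 2 (0.13 log units; within the scatter), because a 1.4-fold higher number from compound 1 to compound 2 (0.13 log units; within the scatter) stayed within the scatter and nothing else here points another way. Compound 4 is therefore expected to give about 11000 nM in this assay, with a likely range from 5500 nM to 24000 nM.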

Compound 4, half-maximal inhibitory concentration: 8950 nM
Compound 4: the middle estimate sits 1.2-fold (0.09 log units) above what was measured; the measured number falls inside the stated range.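

In this assay, putting methoxy in place of chloro on the core of compound 3 gives a 1.0-fold higher number from compound 3 to compound 4 (0.00 log units; within the scatter), so the two compounds cannot be told apart on this read-out. Set beside the earlier example, the change looks alike on both cores as far as these numbers can tell: the same change on two cores in this assay, a 1.4-fold higher number (0.13 log units; within the scatter) from compound 1 to compound 2 and a 1.0-fold higher number (0.00 log units; within the scatter) from compound 3 to compound 4, 1.3-fold (0.13 log units) apart, within the scatter of two such steps. Going by these compounds alone, this shows only that the swap left no readable mark in two cases, with the new group at a different place in each; it does not show that the change would stay this small on any other core, or in any other assay.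

The compounds shown carry only chloro or methoxy at this spot, and all their numbers sit close together, so it stays open whether any group there can move the number beyond the scatter. An amine, a carboxylic acid or a longer chain such as ethoxy in that place would put this to the test.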